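The source may hold more compounds than are shown below. What is called first, only, known or untested is meant among the compounds shown, and "the series" means these compounds.

Compounds measured so far:
- compound 1 `N#Cc1c(-c2ccc(O)cc2)c(C#N)c(=O)n(/N=C/c2cn(-c3ccccc3)nc2-c2ccccc2)c1N`; in an ADME assay on NIH3T3 cells (Mus musculus) for cytotoxicity, read by MTT assay (a higher number here means a weaker inhibitor, a lower number a stronger inhibitor), compound 1 gives 110 ug/mL.
- compound 2 `N#Cc1c(-c2ccc(F)cc2)c(C#N)c(=O)n(/N=C/c2cn(-c3ccccc3)nc2-c2ccccc2)c1N`; in this assay compound 2 reaches only the assay limit of > 200 ug/mL.

Going by the values given here, compound 1 holds the only number given; the other value is a limit. Compound 3 `N#Cc1c(-c2ccccc2C(F)(F)F)c(C#N)c(=O)n(/N=C/c2cn(-c3ccccc3)nc2-c2ccccc2)c1N` differs from compound 1 by 2-(trifluoromethyl)phenyl in place of 4-hydroxyphenyl on an aromatic carbon. Among the compounds with values here, the one step with a bearing is an at least 1.8-fold higher number from compound 1 to compound 2 (0.25 log units; that floor lies within the scatter), which runs into the limit of > 200 ug/mL in this assay, at which 1 of the 2 values shown sits, and so sets only a floor. Both changes remove the hydroxy. For compound 3 a step of a 1.5-fold higher number from compound 1 to compound 3 (0.16 log units; within the scatter) is expected, toward weaker inhibition or none beyond the scatter. Compound 3 is estimated at 160 ug/mL, between 70 ug/mL and 320 ug/mL.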

Compound 3, half-maximal inhibitory concentration: 56 ug/mL
Compound 3: middle estimate off by 2.9-fold (0.46 log units), on the high side, and the stated range ends above it.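

Loss of the hydroxy at this position does not by itself move the number upward in this assay: 2-(trifluoromethyl)phenyl in place of 4-hydroxyphenyl gives a 2.0-fold lower number from compound 1 to compound 3 (0.29 log units; within the scatter). Set against 4-fluorophenyl, the same position shows a difference that clears the scatter, an at least 3.5-fold lower number from compound 2 to compound 3 (0.55 log units; beyond the scatter), so the choice among aryl groups without a hydroxy matters here. That step is only a floor, as compound 2 stands at a limit and not at a number: the limit of > 200 ug/mL in this assay, at which 1 of the 3 values shown sits.

The compounds shown do not separate the trifluoromethyl group from its place on the phenyl ring. On these data alone, how an amine or a carboxylic acid on this ring would read remains open.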